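This account rests on a few compounds, and the source may have more. Where it says the series, first, only, none or still open, it means among the compounds named here.

Among the measured compounds shown here, compound 3 `COc1cc(C(=O)N2CCCC2)nn1-c1ccccc1` stands second highest of the three numbers so far in a functional assay on the whole organism (strain Wistar) for inhibition, with Rattus norvegicus as the target, read by paw edema, with stated times of 30 min and 3 h, at a dose of 100 mg/kg by the oral route (a lower number here means less inhibition, a higher number more inhibition at the dose given (going by the name of the read-out)), where compound 3 gives 29.2%. Its nearest neighbour is compound 2 `CCCCNC(=O)c1cc(OC)n(-c2ccccc2)n1`, which in this assay gives 20.6%; the step of a number 8.6 percentage points higher from compound 2 to compound 3 (within the scatter) lies within the scatter. Furthest off is compound 1 `CNC(=O)c1cc(OC)n(-c2ccccc2)n1`, which gives 57.9%; the step of a number 28.7 percentage points lower from compound 1 to compound 3 (beyond the scatter) is beyond the scatter, as is a number 37.3 percentage points lower from compound 1 to compound 2 (beyond the scatter).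

Compound 4 `COc1cc(C(=O)N2CCCCC2)nn1-c1ccccc1` differs from compound 3 in one place: piperidin-1-yl in place of pyrrolidin-1-yl on a carbonyl carbon. For the measured compounds named here, no measured step bears directly on this change, since compound 3 is the only compound carrying a ring on the amide nitrogen. Going by the values given here, the nearest precedent is the exchange of open chains for pyrrolidin-1-yl, where a number 8.6 percentage points higher from compound 2 to compound 3 (within the scatter) stayed within the scatter while a number 28.7 percentage points lower from compound 1 to compound 3 (beyond the scatter) was modest. Enlarging the ring by one carbon is therefore expected to give at most a small step, a number 4.2 percentage points lower from compound 3 to compound 4 (within the scatter), not beyond the scatter. Compound 4 is estimated at 25%, within 10% to 42%.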

Compound 4, a percentage reported as inhibition, in the whole organism at one dose (the size of the read-out at that dose, not a potency): 28.2%
Compound 4: the middle estimate sits 3.2 percentage points below what was measured; the range from low to high includes it.
By their numbers in this assay, from the lowest: compounds 2, 4 and 3 (each within the scatter of the next); then compound 1.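

In this assay, one carbon more in the ring on the carbonyl carbon gives no readable change (a number 1 percentage points lower from compound 3 to compound 4 (within the scatter)), so piperidin-1-yl and pyrrolidin-1-yl cannot be told apart at this position. The six-membered ring also stands level with the open butylamino chain (a number 7.6 percentage points higher from compound 2 to compound 4 (within the scatter)), while the methylamino amide stays apart (a number 29.7 percentage points lower from compound 1 to compound 4 (beyond the scatter)), and compound 1 is now separated from all three other amides by steps beyond the scatter. Nothing at hand accounts for the level ring pair or for the gap to methylamino.

The compounds shown leave open how the number runs across short open chains, such as ethylamino or dimethylamino, and the unsubstituted amide. They also leave open whether a ring with a second hetero atom, such as morpholin-4-yl, stays level with the two rings.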